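A few compounds are considered here, and "the series" means these few. Any claim that something is new, unique, unknown or untested is made for them only; others in the source may bear on it.

Measured compounds:
- Compound 1 `C/C(=N\Nc1nc(-c2ccccc2)cs1)c1ccc(Cl)c(Cl)c1`: > 50000 nM (a limit of the assay, not a number)
- Compound 2 `C/C(=N\Nc1nc(-c2ccccc2)c(C)s1)c1ccc(Cl)c(Cl)c1`: > 50000 nM (a limit of the assay, not a number)
- Compound 3 `C/C(=N\Nc1nc(-c2ccncc2)cs1)c1ccc(Cl)c(Cl)c1`: 39800 nM

These values come from an ADME assay on J774 cells (Mus musculus) for cytotoxicity, read by resazurin assay, with a stated time of 72 h; on this read-out higher numbers stand for lower toxicity in this test and lower numbers for higher toxicity in this test. Compound 1 stands at the limit of > 50000 nM in this assay, at which 2 of the 3 values shown sit, so its true position is not known as a number.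

Compound 4 `C/C(=N\Nc1nc(-c2cccc([N+](=O)[O-])c2)cs1)c1ccc(Cl)c(Cl)c1` is built from compound 1 by one change: nitro in place of hydrogen on an aromatic carbon. In words, nitro takes the place of hydrogen on an aromatic carbon, meta to a large group.

Two measured steps offer some guidance. Methyl in place of hydrogen on an aromatic carbon gives a step that the two limits leave unreadable from compound 1 to compound 2, so that step sets no size. Pyridin-4-yl in place of phenyl is closer, since it also alters the phenyl group, and it gives an at least 1.2-fold lower number from compound 1 to compound 3 (0.09 log units; that floor lies within the scatter). Neither step shows a change that can be relied on, so only a small move towards a lower number in this assay, or none beyond the scatter, is expected. Another limit would be no surprise.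

The expected step is an at least 1.2-fold lower number from compound 1 to compound 4 (0.09 log units; that floor lies within the scatter). For compound 4 the estimated value is 40000 nM, with an expected range of 15000 nM to 60000 nM.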

Compound 4, half-maximal cytotoxic concentration: > 50000 nM
Compound 4: only a limit was reported; the forecaster's own chance of this, stated with the estimate: 45%; middle value at least 1.2-fold (0.09 log units) away from the limit.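

Compound 1 and compound 4 both end at a limit rather than a number, so no step between them can be read: the limit of > 50000 nM in this assay, at which 3 of the 4 values shown sit.

The compounds shown leave open how far, if at all, nitro in place of hydrogen on an aromatic carbon moves the true value of compound 4 away from that of compound 1.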